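Methyl for bromo on the aroyl ring: compound 3

A few compounds are considered here, and "the series" means these few. Any claim that something is new, unique, unknown or untested is made for them only; others in the source may bear on it.

Measured so far in a functional assay on MCF7 cells (Homo sapiens) for antiproliferative activity, read by sulforhodamine B assay, with a stated time of 72 h, tested at 10 uM; a higher number here means a weaker effect of the compound at the concentration tested, a lower number a stronger effect:
compound 1, `COc1cc(Br)cc2c1OC(N)=C(C#N)C2CC(=O)c1ccc(Cl)cc1` — 49.6%
compound 2, `COc1cc(Br)cc2c1OC(N)=C(C#N)C2CC(=O)c1ccc(Br)cc1` — 39.7%

Within the data shown here, compound 2 is one of only two points, and its only neighbour is compound 1: a number 9.9 percentage points lower from compound 1 to compound 2 (within the scatter). The two numbers therefore cannot be told apart, and nothing in the pair says that bromo in place of chloro on an aromatic carbon moves this assay at all.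

Compound 3 is `COc1cc(Br)cc2c1OC(N)=C(C#N)C2CC(=O)c1ccc(C)cc1`. It differs from compound 2 in one place: methyl in place of bromo on an aromatic carbon, at the place para to a large group of the six-membered aromatic ring of carbon only. Among the measured compounds shown here, no measured step brings a methyl onto that ring; the single step from compound 1 to compound 2 swaps one halogen for another and stayed within the scatter, so it bears on the new step only in showing that the group at this place did not move the read-out between those two compounds. A halogen-to-methyl exchange is unprecedented in the series, so the expectation rests on the neighbourhood alone.

For compound 3 the number is expected near 45%, with a range of 25% to 70%, a change of a number 5.3 percentage points higher from compound 2 to compound 3 (within the scatter) that is estimated to stay within the scatter.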

Compound 3, a percentage reported as activity, at one concentration (the size of the read-out at that concentration, not a potency): 116%
The estimate for compound 3 lay 71 percentage points below the measured number; measured number above the stated range.
By their numbers in this assay, from the lowest: compounds 2 and 1 (each within the scatter of the next); then compound 3.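

In this assay the group at this place, para to a large group, does move the read-out: methyl in place of bromo gives a number 76.3 percentage points higher from compound 2 to compound 3 (beyond the scatter) and methyl in place of chloro gives a number 66.4 percentage points higher from compound 1 to compound 3 (beyond the scatter), whereas the exchange of one halogen for the other had not moved it beyond the scatter. Among these three compounds, chloro and bromo cannot be told apart, and compound 3, with its methyl, shows the weakest effect at the concentration tested, so the 4-bromophenyl to 4-methylphenyl change is what separates the compounds here, and no compound shown goes against this. Nothing measured on these compounds accounts for the size of this step.

The compounds shown leave open whether the effect at this place depends on a halogen as such or only on chloro and bromo, a question that fluoro, iodo, methoxy or an amine at the same carbon would address. They also leave open whether a ring with only hydrogen at this place would read like compound 3 or like the two halogen compounds.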